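This account rests on a few compounds, and the source may have more. Where it says the series, first, only, none or still open, it means among the compounds named here.

Compound 1 `CNC(=O)c1cccnc1NCCCN1CCN(c2ccccc2OC)CC1`: 3.16 nM
Compound 2 `COc1ccccc1N1CCN(CCCNc2ncccc2C(=O)N(C)C)CC1`: 20 nM

Compound 2 has the higher of the two numbers in a functional assay on aorta for antagonist activity at Alpha-1D adrenergic receptor (Rattus norvegicus); a lower number here means tighter binding, a higher number weaker binding; it is separated from compound 1 by a 6.3-fold higher number from compound 1 to compound 2 (0.80 log units; beyond the scatter). Compound 3 `COc1ccccc1N1CCN(CCCNc2ncccc2C(=O)C2CC2)CC1` differs from compound 2 by cyclopropyl in place of dimethylamino on a carbonyl carbon. Going by the values given here, the one measured step, a 6.3-fold higher number from compound 1 to compound 2 (0.80 log units; beyond the scatter), touches the same carbonyl end of the molecule but exchanges a hydrogen for a methyl, not the whole dimethylamino group, so it bears only loosely on this change. Among the compounds with values here, no step exchanges dimethylamino for a carbon ring. The expected step is a 1.3-fold higher number from compound 2 to compound 3 (0.10 log units; within the scatter), within the scatter. Compound 3 is estimated at 25 nM with a range of 8 nM to 80 nM.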

Compound 3, dissociation constant: 2 nM
The estimate for compound 3 lay 13-fold (1.10 log units) above the measured number; measured number outside the range, below it.
By their numbers in this assay, from the lowest: compounds 3 and 1 (each within the scatter of the next); then compound 2.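

On a carbonyl carbon, cyclopropyl in place of dimethylamino gives a 10-fold lower number from compound 2 to compound 3 (1.00 log units; beyond the scatter) in this assay, so a nitrogen on the carbonyl carbon is not required for a low number. Cyclopropyl in place of methylamino gives a 1.6-fold lower number from compound 1 to compound 3 (0.20 log units; within the scatter), which places compound 3, with no amide nitrogen, level with compound 1. No available measurement accounts for these steps.

On these data alone, whether cyclopropyl is specifically needed remains open, since cyclobutyl or isopropyl on the same carbonyl carbon would test ring size and the ring itself. As far as these compounds go, the role of the carbonyl also remains open.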